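The source may report more compounds than this note shows. Statements on the series, on what has been measured and on what is new or still open speak of the compounds shown alone.

Compounds measured in an assay on cells for agonist activity at ecdysone receptor (Bombyx mori), read by a luciferase reporter, with a stated time of 24 h (on this read-out lower numbers stand for an effect already at smaller amounts and higher numbers for an effect only at larger amounts of compound), so far:

compound 1 `Cc1cc(C)cc(C(=O)N(NC(=O)c2ccc(Cl)cc2)C(C)(C)C)c1`: 19.1 nM
compound 2 `Cc1cc(C)cc(C(=O)N(NC(=O)CCC(C)C)C(C)(C)C)c1`: 91.2 nM

Among the compounds with values here, compound 2 stands at the higher of the two numbers, and the single measured step, a 4.8-fold higher number from compound 1 to compound 2 (0.68 log units; beyond the scatter), moved the read-out upward by an amount beyond the scatter. That step exchanged an aromatic group on a carbonyl carbon for a branched saturated chain, so it speaks to the loss of a ring rather than to the shape of the chain itself.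

Compound 3 `CCCCCCCC(=O)NN(C(=O)c1cc(C)cc(C)c1)C(C)(C)C` keeps the core of compound 2 and differs from it by pentyl in place of isopropyl on a saturated chain carbon, two bonds along the chain from a carbonyl carbon. Within the data shown here, no measured step compares two saturated chains with each other, so the only guide is that a chain in this position already gave the higher number of compound 2 in this assay. The change from compound 2 to compound 3 is therefore expected to give at most a small step, a 1.1-fold higher number from compound 2 to compound 3 (0.04 log units; within the scatter), with no clear direction. For compound 3 the estimated value in this assay is 100 nM, within a range from 35 nM to 300 nM.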

Compound 3, half-maximal effective concentration: 97.7 nM
For compound 3 the middle estimate is 1.0-fold (0.01 log units) above the measured one; the measured number falls inside the stated range.
By their numbers in this assay, from the lowest: compound 1; then compounds 2 and 3 (each within the scatter of the next).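

Within the data shown here, compound 3 gives the first comparison of two saturated chains at this position. In this assay, pentyl in place of isopropyl on a saturated chain carbon, two bonds along the chain from a carbonyl carbon, gives a 1.1-fold higher number from compound 2 to compound 3 (0.03 log units; within the scatter), so the linear heptyl and the branched isopentyl cannot be told apart in this assay. The separation from the 4-chlorophenyl compound also holds for both chains: a 5.1-fold higher number from compound 1 to compound 3 (0.71 log units; beyond the scatter) stands beside a 4.8-fold higher number from compound 1 to compound 2 (0.68 log units; beyond the scatter), and both steps lie beyond the scatter, while no available evidence bears on what underlies this result.

The compounds shown leave open whether a much shorter chain such as methyl, or a longer one such as decyl, would stay within the scatter of these two chains, and whether an amine or a carboxylic acid at the end of the chain would matter. They also leave open whether a saturated ring such as cyclohexyl on the same carbonyl carbon would behave like the chains or come closer to compound 1 at 19.1 nM.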